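A few compounds are considered here, and "the series" means these few. Any claim that something is new, unique, unknown or untested is made for them only; others in the source may bear on it.

In a functional assay on DU-145 cells (Homo sapiens) for antiproliferative activity, read by MTT assay, with a stated time of 72 h (a lower number here means a stronger inhibitor, a higher number a weaker inhibitor), the compounds below were compared after a single structural change. Compound 1 `c1ccc(COc2ccc(Nc3ncnc4cc5c(cc34)OCCOCCOCCO5)cc2)cc1` gives only a limit, > 100000 nM. Compound 3 `FC(F)(F)c1ccc(COc2ccc(Nc3ncnc4cc5c(cc34)OCCOCCOCCO5)cc2)cc1` also gives only a limit, > 100000 nM. Between them stands (trifluoromethyl in place of hydrogen on an aromatic carbon), and the step that the two limits leave unreadable from compound 1 to compound 3 cannot be read because of the limit of > 100000 nM in this assay, at which 2 of the 3 values shown sit. Compound 2 `c1ccc(COc2ccccc2Nc2ncnc3cc4c(cc23)OCCOCCOCCO4)cc1` gives a number, 13900 nM; how its core differs from that of compound 1 is not broken down here. Compound 4 `FC(F)(F)c1ccc(COc2ccccc2Nc2ncnc3cc4c(cc23)OCCOCCOCCO4)cc1` is not yet measured and differs from compound 2 by trifluoromethyl in place of hydrogen on an aromatic carbon, the same change as before. The measured pair gives no guide to its size, so the step from compound 2 is expected to be small, a 1.4-fold higher number from compound 2 to compound 4 (0.16 log units; within the scatter). Compound 4 is therefore estimated at 20000 nM, between 5000 nM and 100000 nM.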

Compound 4, half-maximal inhibitory concentration: > 100000 nM
Compound 4 was reported as a limit; the forecaster's own chance of this, stated with the estimate: 25%; middle value at least 5.0-fold (0.69 log units) from the limit.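

Putting trifluoromethyl in place of hydrogen in the series built on compound 2 gives an at least 7.1-fold higher number from compound 2 to compound 4 (0.85 log units; beyond the scatter) in this assay and so a weaker inhibitor. On these data alone, compound 4 gives only a limit of the assay, > 100000 nM and not a number, so the full size of this step stays unknown. The same change on the core of compound 1 cannot be read, so this one step does not show that the effect carries from one core to the other, because the values there stop at the limit: the limit of > 100000 nM in this assay, at which 3 of the 4 values shown sit.

The compounds shown leave open how a different group in place of that hydrogen, such as an amine or a carboxylic acid, would behave. They also leave open whether any such group on the core of compound 1 would give a readable number.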